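A few compounds are considered here, and "the series" means these few. Any claim that something is new, unique, unknown or untested is made for them only; others in the source may bear on it.

Of the compounds shown here, three built on a shared core have been measured in an ADME assay for permeability, using PAMPA, at pH 7.4; on this read-out lower numbers stand for lower permeability and higher numbers for higher permeability. Compound 1 `Cc1cc(NC(=O)Nc2ccccc2OC(F)(F)F)c2ccccc2n1` gives 1110 10^-6 cm/s, compound 2 `CSc1ccc(NC(=O)Nc2cc(C)nc3ccccc23)cc1` gives 473 10^-6 cm/s, and compound 3 `Cc1cc(NC(=O)Nc2cccc3nsnc23)c2ccccc2n1` gives 155 10^-6 cm/s. Compound 2 thus stands second highest of the three: compound 1 sits above it and compound 3 below it, each gap beyond the usual scatter. Compound 4 `Cc1cc(NC(=O)Nc2ccc(O)cc2)c2ccccc2n1` has not yet been measured in this assay. It differs from compound 2 in one place: hydroxy in place of methylsulfanyl on an aromatic carbon. For the measured compounds named here, no measured pair here shows this exact change, so the size of the step is uncertain. The expected step of a 3.2-fold lower number from compound 2 to compound 4 (0.50 log units; beyond the scatter) is downward and beyond the scatter. Compound 4 is estimated at 150 10^-6 cm/s, within a range from 40 10^-6 cm/s to 450 10^-6 cm/s.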

Compound 4, apparent permeability: 3 10^-6 cm/s
The estimate for compound 4 lay 50-fold (1.70 log units) above the measured number; the whole stated range lies above it.
By their numbers in this assay, from the lowest: compound 4; then compound 3; then compound 2; then compound 1.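

In this assay, for the compounds shown here, the pair gives the first single-place change in this set: hydroxy in place of methylsulfanyl, on an aromatic carbon para to a large group, brings a 160-fold lower number from compound 2 to compound 4 (2.20 log units; beyond the scatter). This one position alone can therefore carry a large step, in a change that swaps 0 hydrogen-bond donors for 1 while the acceptor count stays at 1. Nothing measured here accounts for the size of the step. Still open, from the compounds shown here alone, is how a methoxy group or an amine on this same carbon would read, and so whether the drop goes with the donor hydrogen of hydroxy.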